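This account rests on a few compounds, and the source may have more. Where it says the series, first, only, none or still open, it means among the compounds named here.

Compound 1 `Cc1ccc(-n2nncc2CN2C(=O)C3(C(C#N)=C(N)Oc4c3c3nc5ccccc5nc3c3ccccc43)c3ccccc32)cc1C`: in a functional assay on HCT-116 cells (Homo sapiens) for antiproliferative activity, read by MTT assay, with a stated time of 48 h (on this read-out higher numbers stand for weaker inhibition and lower numbers for stronger inhibition), compound 1 gives > 50000 nM, which is a limit of the assay rather than a number.
Compound 2 `Cc1ccccc1-n1nncc1CN1C(=O)C2(C(C#N)=C(N)Oc3c(N)cc4nc5ccccc5nc4c32)c2ccccc21`: in this assay compound 2 gives > 50000 nM, again a limit rather than a number.

Within the data shown here, compound 2 therefore stands at the edge of what this assay can report, and it does not stand there alone: the one further value shown sits at the same place (the limit of > 50000 nM in this assay, at which 2 of the 2 values shown sit). Among the measured compounds shown here, nothing measured here separates the two compounds, so there is no recorded step to lean on.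

Compound 3 `CC(=O)Nc1ccc(-n2nncc2CN2C(=O)C3(C(C#N)=C(N)Oc4c(N)cc5nc6ccccc6nc5c43)c3ccccc32)cc1` has not yet been measured. It differs from compound 2 in a single place: 4-acetamidophenyl in place of 2-methylphenyl on an aromatic nitrogen. For the measured compounds named here, with no step between measured compounds available, there is nothing to show how far a change of this kind moves the result in this assay. Given that both measured compounds sit at the limit, the expectation is no step beyond the usual scatter, in neither direction, and the likeliest outcome is that compound 3 also returns only a limit. The step from compound 2 to compound 3 is expected to be a step that the limit leaves unreadable from compound 2 to compound 3. Compound 3 is estimated at 60000 nM, with a range from 20000 nM to 200000 nM.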

Compound 3, half-maximal inhibitory concentration: > 50000 nM
Compound 3: only a limit was reported; the forecaster's own chance of this, stated with the estimate: 75%; the middle value lies beyond the limit too.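

Compound 3 returns only a limit in this assay, as compound 2 does, so placing 4-acetamidophenyl where 2-methylphenyl stood gives no step that can be read between compound 2 and compound 3, and all the results sit together: the limit of > 50000 nM in this assay, at which 3 of the 3 values shown sit.

The compounds shown leave open what kind of change would give an actual number in this assay.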